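Series notes: aryl sulfanyl diol oxadiazoles, cytotoxicity

A few compounds are considered here, and "the series" means these few. Any claim that something is new, unique, unknown or untested is made for them only; others in the source may bear on it.

Measured compounds:
Compound 1, `CC(O)(CSc1ccc(Cl)cc1)c1nc(-c2ccc(F)c(Cl)c2)no1`: 10000 nM
Compound 2, `CC(O)(CSc1ccc(F)cc1)c1nc(-c2ccc([N+](=O)[O-])c(C(F)(F)F)c2)no1`: 5500 nM
Compound 3, `CC(O)(CSc1ccc(Br)cc1)c1nc(-c2ccc([N+](=O)[O-])c(C(F)(F)F)c2)no1`: 51000 nM

In a functional assay on PC-3 cells (Homo sapiens) for cytotoxicity, read by MTT assay (on this read-out lower numbers stand for stronger inhibition and higher numbers for weaker inhibition), compound 3 stands highest of the three numbers; compound 1 gives a lower number and compound 2 lower still, both gaps beyond the scatter. Compound 4, `CC(O)(CSc1ccccc1)c1nc(-c2ccc([N+](=O)[O-])c(C(F)(F)F)c2)no1`, differs from compound 3 in one place: hydrogen in place of bromo on an aromatic carbon.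

Within the data shown here, one measured step bears on this change. Within the same nitro and trifluoromethyl bearing core, a 9.3-fold higher number from compound 2 to compound 3 (0.97 log units; beyond the scatter); that is, the bromo-bearing compound 3 lies well above the fluoro-bearing compound 2 in this assay. Among the measured compounds shown here, no compound here carries an unsubstituted phenyl on the sulfur side, so the step to hydrogen has no direct precedent. Taking the bromo-to-fluoro difference as the only guide, removing the bromo is expected to bring the number back down, though not with confidence to the level of compound 2. For compound 4 the expected step is a 4.3-fold lower number from compound 3 to compound 4 (0.63 log units; beyond the scatter), and the estimate for compound 4 is 12000 nM with a range of 3500 nM to 40000 nM.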

Compound 4, half-maximal inhibitory concentration: 3500 nM
Compound 4: middle estimate off by 3.4-fold (0.54 log units), on the high side; the range from low to high includes it.
By their numbers in this assay, from the lowest: compounds 4, 2 and 1 (each within the scatter of the next, the first and the last beyond it); then compound 3.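

In this assay on the shared core, the series now reads a 15-fold lower number from compound 3 to compound 4 (1.16 log units; beyond the scatter) and a 1.6-fold lower number from compound 2 to compound 4 (0.20 log units; within the scatter) so the hydrogen and fluoro compounds cannot be told apart, while the bromo compound stands alone. The earlier step could not say whether fluoro lowered the number or bromo raised it; with phenylsulfanyl as the reference, the gap sits with the 4-bromophenyl compound. Nothing shown accounts for this gap.

Open, going by these compounds, is whether a chloro, methyl or methoxy group at this place on the shared core would group with hydrogen and fluoro or with bromo. Also open, on these data alone, is whether the bromo-to-hydrogen step would hold on the core of compound 1, which carries chloro and fluoro on its other aryl ring.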